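The source may report more compounds than this note shows. Statements on the series, on what has been measured and on what is new or still open speak of the compounds shown alone.

Compound 1 `CCCCCc1cc2cn([C@H]3C[C@H](O)[C@@H](CO)O3)c(=O)nc2o1` in a functional assay on HEL cells (Homo sapiens) for cytotoxicity (a lower number here means that less compound is tolerated, a higher number that more compound is tolerated), gives > 50000 nM, which is a limit of the assay rather than a number.
Compound 2 `CCCCCCCc1cc2cn([C@H]3C[C@H](O)[C@@H](CO)O3)c(=O)nc2o1` in this assay gives > 50000 nM, again a limit of the assay.
Compound 3 `CCCCCCCCc1cc2cn([C@H]3C[C@H](O)[C@@H](CO)O3)c(=O)nc2o1` in this assay gives > 50000 nM, once more a limit of the assay.

Among the measured compounds shown here, compound 3 therefore stands at the limit of this assay, and the two other values shown sit at that same limit; the only evidence on the measured steps is the limit of > 50000 nM in this assay, at which 3 of the 3 values shown sit. The steps between the measured compounds, a step that the two limits leave unreadable from compound 1 to compound 2, a step that the two limits leave unreadable from compound 1 to compound 3 and a step that the two limits leave unreadable from compound 2 to compound 3, cannot be read in size or direction, since both ends of each lie at the limit.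

Compound 4 `CCCCCCCCCc1cc2cn([C@H]3C[C@H](O)[C@@H](CO)O3)c(=O)nc2o1` differs from compound 3 by methyl in place of hydrogen on a saturated chain carbon, eight bonds along the chain from an aromatic carbon. The step from compound 2 to compound 3 is the measured change of the same kind along this chain, methyl in place of hydrogen, but its size is not readable, so no direction of step beyond the scatter can be expected from it. The expected step of a number no higher from compound 3 to compound 4 (the limit leaves the size open) thus amounts to no change that the assay would show. Compound 4 is estimated to give 50000 nM in this assay, in a range from 20000 nM to 100000 nM, most probably reported once more as a limit.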

Compound 4, minimum cytotoxic concentration: > 200000 nM
Compound 4 ended at the assay's limit; the forecaster's own chance of this, stated with the estimate: 85%; middle value at least 4.0-fold (0.60 log units) away from the limit.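

In this assay compound 4 gives > 200000 nM, which is a limit of the assay. All four compounds stand at limits, and the steps from compound 1, compound 2 and compound 3 to compound 4 cannot be read. The compounds shown leave open at what concentration any of them becomes cytotoxic, and whether lengthening the chain changes that concentration.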